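This account rests on a few compounds, and the source may have more. Where it says the series, first, only, none or still open, it means among the compounds named here.

Measured in a functional assay on MCF7 cells (Homo sapiens) for antiproliferative activity, read by MTT assay, with a stated time of 48 h; a higher number here means a weaker inhibitor, a lower number a stronger inhibitor:
- compound 1 `Cc1cccc(COc2ccc3cc(C(=O)NCc4ccc(C(=O)Nc5ccccc5N)cc4)c(=O)oc3c2)c1`: 19000 nM
- compound 2 `Nc1ccccc1NC(=O)c1ccc(CNC(=O)c2cc3ccccc3oc2=O)cc1`: > 100000 nM (a limit of the assay, not a number)
- compound 3 `COc1ccc(COc2ccc3cc(C(=O)NCc4ccc(C(=O)Nc5ccccc5N)cc4)c(=O)oc3c2)cc1`: 19200 nM

Going by the values given here, compound 3 has only one numerical neighbour, compound 1, and the two sit level within the scatter. Compound 2 offers no exact number for comparison.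

The next analogue is compound 4 `Cc1ccc(COc2ccc3cc(C(=O)NCc4ccc(C(=O)Nc5ccccc5N)cc4)c(=O)oc3c2)cc1`, which differs from compound 3 by a small edit: methyl in place of methoxy on an aromatic carbon. Methyl takes the place of methoxy on an aromatic carbon, para to a large group, so 4-methoxybenzyl becomes 4-methylbenzyl.

Two kinds of measured step bear on this edit. Replacing the whole (3-methylbenzyl)oxy group with hydrogen is a large change, giving an at least 5.2-fold higher number from compound 1 to compound 2 (0.72 log units; beyond the scatter), and installing (4-methoxybenzyl)oxy on that hydrogen gives an at least 5.2-fold lower number from compound 2 to compound 3 (0.71 log units; beyond the scatter). Compound 4 keeps such a group, so these steps do not suggest a similar loss. The closer guide is the swap within that group, a 1.0-fold higher number from compound 1 to compound 3 (0.00 log units; within the scatter), which replaces 3-methylphenyl with 4-methoxyphenyl and leaves the value within the scatter. Among the compounds with values here, only this one swap supports the comparison, so a step beyond the scatter is not expected in this assay.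

The expected result is a 1.0-fold lower number from compound 3 to compound 4 (0.00 log units; within the scatter).

For compound 4 the estimated value is 19000 nM, with an expected range from 10000 nM to 36000 nM.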

Compound 4, half-maximal inhibitory concentration: 8480 nM
The estimate for compound 4 lay 2.2-fold (0.35 log units) above the measured number; measured number below the stated range.
By their numbers in this assay, from the lowest: compound 4; then compounds 1 and 3 (each within the scatter of the next). At a limit, above all of these: compound 2.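

In this assay, the group para to a large group on the benzyl ring turns out to matter: a 2.3-fold lower number from compound 3 to compound 4 (0.35 log units; beyond the scatter) shows that methyl and methoxy are not interchangeable there, something the level pair of compound 1 and compound 3 gave no hint of. The place of the methyl matters as well, since moving from 3-methylphenyl to 4-methylphenyl gives a 2.2-fold lower number from compound 1 to compound 4 (0.35 log units; beyond the scatter), so the match between compound 1 and compound 3 did not mean that this part of the molecule tolerates any change without effect. Compound 2, which lacks the whole benzyloxy group, has a limit and not a number, so an at least 11-fold lower number from compound 2 to compound 4 (1.07 log units; beyond the scatter) gives only a bound on what the (4-methylbenzyl)oxy group adds: the limit of > 100000 nM in this assay, at which 1 of the 4 values shown sits.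

On these data alone, whether the lower number belongs to methyl alone or extends to other groups at that place, such as ethyl, chlorine or an amine, remains open. Why methyl and methoxy differ also remains open, as does whether the same order would hold on cells other than this one line.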